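Swapping the group on the oxygen of compound 3

The compounds below may be only part of what the source reports. "The series", "measured", "known", "first", "only" and "open" are said of these compounds alone.

Compound 1 `CCOc1cc(-c2ccc3cc[nH]c3c2)cn2c(-c3cc(OC)c(OC)c(OC)c3)nnc12` gives 272 nM
Compound 2 `COc1cc(-c2nnc3c(OC(C)C)cc(-c4ccc5[nH]ccc5c4)cn23)cc(OC)c1OC` gives 261 nM
Compound 3 `COc1cc(-c2nnc3c(OC(C)C)cc(-c4ccc5c(ccn5C)c4)cn23)cc(OC)c1OC` gives 503 nM

In a functional assay on HeLa cells (Homo sapiens) for antiproliferative activity, read by MTT assay, with a stated time of 48 h (on this read-out lower numbers stand for stronger inhibition and higher numbers for weaker inhibition), compound 3 at 503 nM stands within the scatter of both compound 1 and compound 2, so these values cannot be ranked. The change leading to compound 4 `CCCN1CC(Oc2cc(-c3ccc4c(ccn4C)c3)cn3c(-c4cc(OC)c(OC)c(OC)c4)nnc23)C1` reads 1-propylazetidin-3-yl in place of isopropyl on an oxygen on an aromatic ring in a single place: 1-propylazetidin-3-yl in place of isopropyl on an oxygen on an aromatic ring. Among the compounds with values here, no measured step touches this group. Within the data shown here, the one step available, a 1.9-fold higher number from compound 2 to compound 3 (0.28 log units; within the scatter) for methyl in place of hydrogen on an aromatic nitrogen, concerns a different change and stays within the scatter. With nothing measured for such a group on the oxygen, the data give no direction, and no step beyond the scatter is expected in this assay although the uncertainty is wide. The expected change is a 1.1-fold lower number from compound 3 to compound 4 (0.05 log units; within the scatter) on this estimate. For compound 4 the estimated value is 450 nM with a range from 120 nM to 1800 nM in this read-out.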

Compound 4, half-maximal inhibitory concentration: 211 nM
For compound 4 the middle estimate is 2.1-fold (0.33 log units) above the measured one, within the range that was stated.
By their numbers in this assay, from the lowest: compounds 4, 2, 1 and 3 (each within the scatter of the next, the first and the last beyond it).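

In this assay, the group on the oxygen on an aromatic ring is the first place among these compounds where a change goes beyond the scatter: 1-propylazetidin-3-yl in place of isopropyl gives a 2.4-fold lower number from compound 3 to compound 4 (0.38 log units; beyond the scatter), a modest step. The earlier step, on the aromatic nitrogen, stayed within the scatter, so this oxygen substituent is the one place shown where the number moves measurably. Nothing given here bears on the reason for this step.

The compounds shown do not separate the contributions of the four-membered ring, its nitrogen and the propyl chain on that nitrogen, which all enter together. An azetidine with a free ring amine, a longer chain on that nitrogen or an open-chain amine on the oxygen would pull these apart.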